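Swapping a Dichlorophenyl Ether for a Fluorophenyl Ether

The source may hold more compounds than are shown below. What is called first, only, known or untested is meant among the compounds shown, and "the series" means these compounds.

Measured compounds:
compound 1, `Nc1cc(N)c2nc(-c3ccccc3)c(Oc3ccc(Cl)c(Cl)c3)nc2c1`, in a functional assay on IGROV-1 cells (Homo sapiens) for inhibition, read by sulforhodamine B assay, with a stated time of 48 h (on this read-out higher numbers stand for weaker inhibition of growth and lower numbers for stronger inhibition of growth), gives 32400 nM
compound 2, `CCOC(=O)[C@H](CCC(=O)O)NC(=O)c1ccc(Sc2nc3cc(N)cc(N)c3nc2-c2ccccc2)cc1`, in this assay reaches only a limit of the assay, < 100000 nM
compound 3, `CCOC(=O)[C@H](CCC(=O)O)NC(=O)c1ccc(Oc2nc3cc(N)cc(N)c3nc2-c2ccccc2)cc1`, in this assay gives 79400 nM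

All three share one core, a diamine-bearing ring system carrying a phenyl group and an ether or thioether link to a second aromatic ring. In this assay compound 1 has the lowest of the two real numbers; compound 3 sits higher by a gap beyond the usual scatter. Compound 2 contributes only a limit (the limit of < 100000 nM in this assay, at which 1 of the 3 values shown sits), so no ranking against it is possible.

Compound 4, `Nc1cc(N)c2nc(-c3ccccc3)c(Oc3ccc(F)cc3)nc2c1`, has not yet been measured. It differs from compound 1 by 4-fluorophenyl in place of 3,4-dichlorophenyl on an oxygen on an aromatic ring. Within the data shown here, no measured pair shows the effect of such a change, so the expectation rests on compound 1 alone. The step from compound 1 to compound 4 in this assay is expected to be small to moderate, toward weaker inhibition, at a 1.5-fold higher number from compound 1 to compound 4 (0.19 log units; within the scatter). Compound 4 is therefore expected to give 50000 nM in this assay, within a range from 15000 nM to 150000 nM.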

Compound 4, concentration for total growth inhibition: < 100000 nM
Compound 4 gave a limit, no number; the forecaster's own chance of this, stated with the estimate: 20%; the middle value is on the limit's open side.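

In this assay compound 4 gives only a limit of the assay, < 100000 nM, not a number. Among these compounds, no step from compound 1 to compound 4 can therefore be read. The compounds shown leave open whether 4-fluorophenyl in place of 3,4-dichlorophenyl changes growth inhibition at all, and several of the values rest on one limit: the limit of < 100000 nM in this assay, at which 2 of the 4 values shown sit.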